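Swapping (dimethylcarbamoyl)methyl for isopropyl: notes on compound 4

A few compounds are considered here, and "the series" means these few. Any claim that something is new, unique, unknown or untested is made for them only; others in the source may bear on it.

Compound 2 `CN(C)C(=O)Cn1cc(C(=O)Nc2ccc(-c3cn(C)c4ncnc(N)c34)cc2)c(=O)c(-c2ccc(F)cc2)c1` gives > 100 nM in a functional assay on MKN-45 cells (Homo sapiens) for antiproliferative activity, with a stated time of 72 h (a higher number here means a weaker inhibitor, a lower number a stronger inhibitor), and this is a limit of the assay, not a number. Compound 2 therefore has no exact place on the scale: the limit of > 100 nM in this assay, at which 1 of the 3 values shown sits, and the other two compounds give numbers. Compound 1 `Nc1ncnc2[nH]cc(-c3ccc(NC(=O)c4cn(CC5CCOCC5)cc(-c5ccc(F)cc5)c4=O)cc3)c12` gives 77.9 nM in this assay and compound 3 `CC(C)n1cc(C(=O)Nc2cc(F)c(-c3c[nH]c4ncnc(N)c34)cc2F)c(=O)c(-c2ccc(F)cc2)c1` gives 13.2 nM there.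

Compound 4 `CC(C)n1cc(C(=O)Nc2ccc(-c3cn(C)c4ncnc(N)c34)cc2)c(=O)c(-c2ccc(F)cc2)c1` differs from compound 2 in one place, with isopropyl in place of (dimethylcarbamoyl)methyl on an aromatic nitrogen. For the measured compounds named here, no measured pair isolates this change. The nearest guide is compound 3, which also carries isopropyl and gives 13.2 nM in this assay but differs from compound 4 elsewhere as well, so it supports a direction more than a size. A move to stronger inhibition, beyond the scatter, is expected, with an at least 3.3-fold lower number from compound 2 to compound 4 (0.52 log units; beyond the scatter) as the estimated size. Compound 4 is expected at 30 nM in this assay with 9 nM to 95 nM as the estimated range.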

Compound 4, half-maximal inhibitory concentration: 85.3 nM
Estimate against measurement, compound 4: 2.8-fold (0.45 log units) below; measured number inside the range.
By their numbers in this assay, from the lowest: compound 3; then compounds 1 and 4 (each within the scatter of the next). At a limit, above all of these: compound 2.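

With isopropyl on the aromatic nitrogen, the core shared by compound 2 and compound 4 now has an exact number in this assay, where compound 2 offered only a limit. The change reads as an at least 1.1-fold lower number from compound 2 to compound 4 (0.06 log units; that floor lies within the scatter), so a gain from replacing (dimethylcarbamoyl)methyl with isopropyl is not established, although a real gain of unknown size remains possible. The step is only a floor because compound 2 stands at a limit: the limit of > 100 nM in this assay, at which 1 of the 4 values shown sits.

As far as these compounds go, the true size of the step remains open, as does whether the larger (dimethylcarbamoyl)methyl group costs anything at this position. Also open, from the compounds shown here alone, is where a carboxylic acid, an aminoethyl chain or a plain ethyl group on this aromatic nitrogen would fall against compound 4 in this assay.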